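Compound 3 and an added amino group

The source may hold more compounds than are shown below. What is called first, only, known or untested is meant among the compounds shown, and "the series" means these compounds.

In a functional assay on MCF7 cells (Homo sapiens) for cytotoxicity, read by MTT assay, with a stated time of 3 days (a lower number here means a stronger inhibitor, a higher number a weaker inhibitor), compound 1 `COc1ccc(-c2ccccc2)cc1` gives > 100 ug/mL, which is a limit and not a number. Compound 3 `COc1ccc(-c2ccccc2)c(OC)c1` gives > 100 ug/mL, likewise a limit, and so stands at the limit of > 100 ug/mL in this assay, at which 2 of the 3 values shown sit. Methoxy in place of hydrogen on an aromatic carbon is a step that the two limits leave unreadable from compound 1 to compound 3, so it offers no size to carry forward. Among the measured compounds shown here, compound 2 `Nc1cccc(-c2ccc(O)cc2)c1` gives 6.5 ug/mL, the only number, and it is the only measured compound carrying amino. Compound 4 `COc1ccc(-c2cccc(N)c2)c(OC)c1` departs from compound 3 by amino in place of hydrogen on an aromatic carbon. For the measured compounds named here, no measured step shows this change, so a move towards stronger inhibition is expected only tentatively, on the value of compound 2 at 6.5 ug/mL. The expected step is an at least 4.0-fold lower number from compound 3 to compound 4 (0.60 log units; beyond the scatter). Compound 4 is estimated at 25 ug/mL, with an expected range of 6 ug/mL to 100 ug/mL.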

Compound 4, half-maximal inhibitory concentration: > 100 ug/mL
Compound 4: a limit, no number (the forecaster's own chance of this, stated with the estimate: 35%); at least 4.0-fold (0.60 log units) between middle value and limit.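

Compound 3 and compound 4 each give only a limit, so no size can be read for the amino step between them: the limit of > 100 ug/mL in this assay, at which 3 of the 4 values shown sit.

Which structural feature sets compound 2 apart at 6.5 ug/mL stays open.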